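Limit values and the step to compound 4

A few compounds are considered here, and "the series" means these few. Any claim that something is new, unique, unknown or untested is made for them only; others in the source may bear on it.

Values in an ADME assay on MRC5 cells (Homo sapiens) for inhibition, with a stated time of 72 h (on this read-out lower numbers stand for an effect already at smaller amounts and higher numbers for an effect only at larger amounts of compound), each one a limit:
- compound 1 `COc1cccc(OC)c1C(=O)Nc1c[nH]nc1C(=O)NC1CC2CCC1C2` gives > 50000 nM
- compound 2 `COc1cccc(OC)c1C(=O)Nc1c[nH]nc1C(=O)NC1CCC1` gives > 50000 nM
- compound 3 `COc1cccc(OC)c1C(=O)Nc1c[nH]nc1C(=O)NCCCOC(C)C` gives > 50000 nM

Compound 3 has no number of its own and stands with the others at the limit of > 50000 nM in this assay, at which 3 of the 3 values shown sit. Compound 4 `COc1cccc(OC)c1C(=O)Nc1c[nH]nc1C(=O)NC1CCC(C)CC1` carries 4-methylcyclohexyl in place of 3-isopropoxypropyl on an amide-type nitrogen. The measured changes at that nitrogen are a step that the two limits leave unreadable from compound 1 to compound 2, a step that the two limits leave unreadable from compound 1 to compound 3 and a step that the two limits leave unreadable from compound 2 to compound 3, so none gives a size to carry over. Another limit is the likeliest result, with no direction expected. The estimated step is a number no higher from compound 3 to compound 4 (the limit leaves the size open), expected to stay within the scatter. Compound 4 is estimated at 50000 nM, with an expected range from 20000 nM to 120000 nM.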

Compound 4, half-maximal effective concentration: 45000 nM
Compound 4: middle estimate off by 1.1-fold (0.05 log units), on the high side; the measured number falls inside the stated range.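

At the amide-type nitrogen, compound 4 is the only compound shown with an actual number in this assay, while the other three compounds each give only a limit: the limit of > 50000 nM in this assay, at which 3 of the 4 values shown sit. Against those limits, the change to 4-methylcyclohexyl reads as an at least 1.1-fold lower number from compound 3 to compound 4 (0.04 log units; that floor lies within the scatter), as an at least 1.1-fold lower number from compound 2 to compound 4 (0.04 log units; that floor lies within the scatter) and as an at least 1.1-fold lower number from compound 1 to compound 4 (0.04 log units; that floor lies within the scatter). These steps are floors, so a ring of this kind at this position gives no true step size.

The compounds shown leave open what an amine or a carboxylic acid on this nitrogen would give. Changes elsewhere on the shared core also remain open.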